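Amide aryl swap and solubility in the series

A few compounds are considered here, and "the series" means these few. Any claim that something is new, unique, unknown or untested is made for them only; others in the source may bear on it.

Compound 2 `CC(C)(C)c1cc(C(=O)Nc2ccccn2)n(Cc2ccccc2)n1` gives 25 ug/mL in a physicochemical assay for solubility, read by nephelometry, measured as kinetic solubility, at pH 2.0 (a higher number here means a more soluble compound, a lower number a less soluble compound), the highest of the two numbers in the set. Compound 3 `CC(C)(C)c1cc(C(=O)Nc2nc(CNS(C)(=O)=O)cs2)n(Cc2ccccc2)n1` gives 3.1 ug/mL, a value that sits below it beyond the scatter. Compound 1 `NCc1csc(NC(=O)c2ncccn2)n1` sits at the assay limit, > 100 ug/mL, which is not a number. The step to compound 4 `CC(C)(C)c1cc(C(=O)Nc2cccc(CN)c2)n(Cc2ccccc2)n1` brings (3-(aminomethyl)phenyl in place of pyridin-2-yl on an amide-type nitrogen). Among the measured compounds shown here, no measured pair shows this change, so the expected step is read from the set: compound 1, carrying an aminomethyl group, sits at the limit (the limit of > 100 ug/mL in this assay, at which 1 of the 3 values shown sits). A rise beyond the scatter is expected, a 4.8-fold higher number from compound 2 to compound 4 (0.68 log units; beyond the scatter). Compound 4 is estimated at 120 ug/mL, range 40 ug/mL to 300 ug/mL, with a fair chance that this assay reports only its limit.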

Compound 4, solubility: > 100 ug/mL
Compound 4 ended at the assay's limit; the forecaster's own chance of this, stated with the estimate: 60%; the middle value is on the limit's open side.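

Among the compounds shown here, at the amide-type nitrogen, 3-(aminomethyl)phenyl in place of pyridin-2-yl gives the only single-place step on this core in this assay, an at least 4.0-fold higher number from compound 2 to compound 4 (0.60 log units; beyond the scatter). Compound 4 gives > 100 ug/mL, which is a limit of the assay, so the step has a lower bound but no measured size. A compound on this core now stands at the limit: the limit of > 100 ug/mL in this assay, at which 2 of the 4 values shown sit.

Whether the aminomethyl group or the change of ring accounts for the step remains open. A phenyl ring carrying hydroxymethyl or methyl in place of aminomethyl would separate the two.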